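Lifting Compound 1 With a Longer Side Chain

The source may report more compounds than this note shows. Statements on the series, on what has been measured and on what is new or still open speak of the compounds shown alone.

- compound 1 `Cc1c(Cc2ccc(F)cc2)c(=O)oc2cc(OCCOc3no[n+]([O-])c3S(=O)(=O)c3ccccc3)ccc12` gives 0.01 ug/mL in a physicochemical assay for solubility, read by HPLC, in phosphate buffer, with a stated time of 24 h; a lower number here means a less soluble compound, a higher number a more soluble compound
- compound 2 `O=C(N/N=C/c1ccc(F)cc1)c1ccc(OCCOc2no[n+]([O-])c2S(=O)(=O)c2ccccc2)cc1O` gives 8.2 ug/mL in this assay
- compound 3 `COc1ccc(/C=N/NC(=O)c2ccc(OCCOc3no[n+]([O-])c3S(=O)(=O)c3ccccc3)cc2OC)cc1` gives 6.3 ug/mL in this assay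

Compound 1 stands lowest of the three, and its gaps to compound 2 and compound 3 both lie beyond the scatter. Compound 4 `Cc1c(CCC(=O)NCc2ccc(F)cc2)c(=O)oc2cc(OCCOc3no[n+]([O-])c3S(=O)(=O)c3ccccc3)ccc12` keeps the core of compound 1 but carries ((4-fluorobenzyl)carbamoyl)methyl in place of 4-fluorophenyl on a saturated chain carbon bound to an aromatic carbon. Within the data shown here, no measured pair shows this change. Compound 1 lies so far under compound 3 (6.3 ug/mL) that an upward step beyond the scatter in this assay is expected, though a modest one. The estimated step is an 8.0-fold higher number from compound 1 to compound 4 (0.90 log units; beyond the scatter), as an expectation only. For compound 4 the estimate is 0.08 ug/mL, with an expected range from 0.015 ug/mL to 0.8 ug/mL.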

Compound 4, solubility: 0.7 ug/mL
For compound 4 the middle estimate is 8.8-fold (0.94 log units) below the measured one; the range from low to high includes it.
By their numbers in this assay, from the lowest: compound 1; then compound 4; then compounds 3 and 2 (each within the scatter of the next).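

Among these compounds, on a saturated chain carbon bound to an aromatic carbon, ((4-fluorobenzyl)carbamoyl)methyl in place of 4-fluorophenyl gives in this assay a 70-fold higher number from compound 1 to compound 4 (1.85 log units; beyond the scatter) and so provides the first step that can be read at this position. The earlier compounds shown here offered no pair differing in one place. No measurement shown accounts for the size of this step.

As far as these compounds go, whether the amide hydrogen, the carbonyl or the longer chain carries the step remains open. So does whether an amine or a carboxylic acid on the same chain would move the number the same way.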